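The source may hold more compounds than are shown below. What is called first, only, known or untested is meant among the compounds shown, and "the series" means these compounds.

Measured compounds:
- Compound 1, `COc1ccc(C(=O)c2cc(OC)c(OC)c(OC)c2)cc1N`: 200 nM
- Compound 2, `C#CCOc1cccc(/C=C/C(=O)Nc2cc(C(=O)c3cc(OC)c(OC)c(OC)c3)ccc2OC)c1`: 13400 nM
- Compound 3, `COc1ccc(C(=O)c2cc(OC)c(OC)c(OC)c2)cc1NC(=O)/C=C/c1cccc(OC(F)(F)F)c1`: 7900 nM

In a functional assay on COLO 205 cells (Homo sapiens) for cytotoxicity, read by MTT assay, with a stated time of 72 h (a higher number here means a weaker inhibitor, a lower number a stronger inhibitor), compound 3 gives 7900 nM, the second highest of the three numbers. Its nearest neighbour is compound 2, and the step of a 1.7-fold lower number from compound 2 to compound 3 (0.23 log units; within the scatter) lies within the scatter, so the two cannot be told apart. Where compounds 2 and 3 carry the acrylamide, compound 1 carries a free amine; compound 1 gives 200 nM, a number far lower than that of compound 3 and beyond the scatter.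

Compound 4, `COc1ccc(C(=O)c2cc(OC)c(OC)c(OC)c2)cc1NC(=O)/C=C/c1ccc(N)cc1`, is not yet measured. It differs from compound 3 in one place: 4-aminophenyl in place of 3-(trifluoromethoxy)phenyl on a double-bonded chain carbon bound to a double-bonded chain carbon. Going by the values given here, the only measured step that touches the same aryl ring is a 1.7-fold lower number from compound 2 to compound 3 (0.23 log units; within the scatter), which exchanges one oxygen substituent for another and stays within the scatter. Among the compounds with values here, no measured step shows an amine entering this ring, so the expectation rests on that single step and on the shared acrylamide core of compounds 2 and 3. The step of a 1.3-fold lower number from compound 3 to compound 4 (0.12 log units; within the scatter) is therefore expected to stay within the scatter. Compound 4 is estimated at 6000 nM, within the range 1500 nM to 25000 nM.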

Compound 4, half-maximal inhibitory concentration: 10300 nM
Compound 4: middle estimate off by 1.7-fold (0.23 log units), on the low side; low and high end bracket the measured number.
By their numbers in this assay, from the lowest: compound 1; then compounds 3, 4 and 2 (each within the scatter of the next).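

In this assay, placing 4-aminophenyl on the double-bonded chain carbon makes no readable difference, with a 1.3-fold higher number from compound 3 to compound 4 (0.12 log units; within the scatter) and a 1.3-fold lower number from compound 2 to compound 4 (0.11 log units; within the scatter). The three aryl rings tried at this position, now including one with an amine rather than an oxygen substituent, therefore cannot be told apart. Going by these compounds alone, the large gap lies elsewhere, with a 52-fold higher number from compound 1 to compound 4 (1.71 log units; beyond the scatter): the earlier compounds showed such a gap only for rings with oxygen substituents, and it now holds for the amine-bearing ring too. Nothing measured here explains either the flat result at the ring or the large step at the nitrogen.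

The compounds shown leave open whether a small acetyl group on that nitrogen would give a number as high as the full chain does. They also leave open whether a carboxylic acid on the aryl ring would move the number at all.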